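The compounds below may be only part of what the source reports. "The series", "measured", "known", "first", "only" and "open" are said of these compounds alone.

Among the measured compounds shown here, compound 1 `C=CCOC(=O)C1=C2C(=NC1=O)c1cccc3c(SCCC)ccc2c13` carries the only true number in an ADME assay on WI-38 cells (Homo sapiens) for antiproliferative activity, read by sulforhodamine B assay, with a stated time of 72 h (on this read-out higher numbers stand for weaker inhibition and lower numbers for stronger inhibition), where compound 1 gives 33200 nM. Compound 2 `CCCSC(=O)COC(=O)C1=C2C(=NC1=O)c1cccc3c(SCCC)ccc2c13` reads > 100000 nM, which is a limit of this assay and not a number. For the measured compounds named here, the one measured step, an at least 3.0-fold higher number from compound 1 to compound 2 (0.47 log units; beyond the scatter), puts (propylsulfanyl)carbonyl in place of vinyl on a saturated chain carbon bound to an oxygen next to a carbonyl group. Compound 3 `C=CCOC(=O)C1=C2C(=NC1=O)c1cccc3c(SCC=C)ccc2c13` keeps that part of compound 1 and changes elsewhere: vinyl in place of ethyl on a saturated chain carbon bound to a sulfur. Here vinyl takes the place of ethyl on a saturated chain carbon bound to a sulfur, turning propylsulfanyl into allylsulfanyl. Going by the values given here, no measured step touches this place, so an at least 3.0-fold higher number from compound 1 to compound 2 (0.47 log units; beyond the scatter) gives no direct guide. The expected change, a 1.1-fold lower number from compound 1 to compound 3 (0.04 log units; within the scatter), stays within the usual scatter, in neither direction. For compound 3 the estimated value is 30000 nM, with an expected range of 12000 nM to 75000 nM.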

Compound 3, half-maximal inhibitory concentration: 19700 nM
For compound 3 the middle estimate is 1.5-fold (0.18 log units) above the measured one; measured number inside the range.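

Turning propylsulfanyl into allylsulfanyl gives a 1.7-fold lower number from compound 1 to compound 3 (0.23 log units; within the scatter). Among the compounds shown here, this is the first measured step in this place, and it shows that a double bond can enter the chain on the sulfur without a change that can be told from the usual scatter. The earlier step, an at least 3.0-fold higher number from compound 1 to compound 2 (0.47 log units; beyond the scatter), lay in a different place and went beyond the scatter, whereas this one does not.

With only this one swap shown, it remains open whether a longer chain such as butyl, or a chain ending in an amine or a carboxylic acid, would move the number beyond the scatter. Nothing shown here bears on this result or offers a reason for it.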